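Swapping an ethyl for a chloro on the aryl ring

A few compounds are considered here, and "the series" means these few. Any claim that something is new, unique, unknown or untested is made for them only; others in the source may bear on it.

Measured so far:
compound 1 `CCc1cccc(C[C@H](O)/C=C/[C@H]2COC(=O)N2CCSCCCC(=O)O)c1` gives 2400 nM
compound 2 `O=C(O)CCCSCCN1C(=O)SC[C@@H]1/C=C/[C@@H](O)Cc1cccc(C(F)(F)F)c1` gives > 10000 nM
compound 3 `Cc1cccc(C[C@H](O)/C=C/[C@H]2CCC(=S)N2CCSCCCC(=O)O)c1` gives 2800 nM

All three were tested in an assay on CHO cells for displacement of a labelled ligand from prostaglandin E2 receptor EP1 subtype (Mus musculus), read by scintillation counting, with a stated time of 20 min; a lower number here means a stronger inhibitor, a higher number a weaker inhibitor. Compound 1 has the lowest of the two numbers shown in this assay, at 2400 nM. Compound 3 sits closest to it, with 2800 nM, and the gap between them is within the scatter of this measurement, so neither can be called the stronger inhibitor. For compound 2 the assay reports only a limit, > 10000 nM, not a number; this is the limit of > 10000 nM in this assay, at which 1 of the 3 values shown sits.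

The unmeasured compound 4 `O=C(O)CCCSCCN1C(=O)OC[C@@H]1/C=C/[C@@H](O)Cc1cccc(Cl)c1` keeps the whole core of compound 1 and differs from it only on the aromatic ring: chloro in place of ethyl on an aromatic carbon. The change sits on an aromatic carbon of a six-membered aromatic ring of carbon only, meta to a large group. Among the compounds with values here, nothing among the measured compounds directly reports what such a swap does here. The estimated step from compound 1 to compound 4 in this assay is therefore a 1.0-fold higher number from compound 1 to compound 4 (0.02 log units; within the scatter), a change not expected to go beyond the scatter. Compound 4 is expected to give about 2500 nM, with a likely range from 1000 nM to 7000 nM.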

Compound 4, inhibition constant: > 10000 nM
Compound 4 gave a limit, no number (the forecaster's own chance of this, stated with the estimate: 10%); at least 4.0-fold (0.60 log units) between middle value and limit.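

The swap from ethyl to chloro on the aromatic ring is not neutral: in this assay it gives an at least 4.1-fold higher number from compound 1 to compound 4 (0.61 log units; beyond the scatter). Within the data shown here, with the rest of the core of compound 1 unchanged, this single position on the ring is enough to change the result beyond the scatter, which the earlier compounds could not show, as no two of them differed in one place only. From the compounds shown here alone, compound 4 has a limit and not a number, so the full size of the step stays unknown, and this is the same limit recorded for compound 2: the limit of > 10000 nM in this assay, at which 2 of the 4 values shown sit.

Compounds 2 and 3 carry trifluoromethyl and methyl on this ring, but each also differs from compound 1 elsewhere, so neither settles what those groups do here. Going by these compounds, how a methoxy group or a longer chain such as propyl would behave at this position on the core of compound 1 also remains open.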